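Working notes: one more methyl on the amine chain

A few compounds are considered here, and "the series" means these few. Any claim that something is new, unique, unknown or untested is made for them only; others in the source may bear on it.

compound 1 `Clc1ccc(CCCN2CCC(COC(c3ccccc3)c3ccccc3)CC2)cc1`: 500 nM
compound 2 `CCCN1CCC(COC(c2ccccc2)c2ccccc2)CC1`: 17800 nM
compound 3 `CCCCN1CCC(COC(c2ccccc2)c2ccccc2)CC1`: 14000 nM
compound 4 `CCCCCN1CCC(COC(c2ccccc2)c2ccccc2)CC1`: not yet measured

All values come from a functional assay on cells (T-cell line, Homo sapiens) for inhibition; on this read-out lower numbers stand for stronger inhibition and higher numbers for weaker inhibition. Compound 3 stands at the high end of these numbers, level with compound 2, and far from compound 1: a 28-fold higher number from compound 1 to compound 3 (1.45 log units; beyond the scatter).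

The change to compound 4 is methyl in place of hydrogen on a saturated chain carbon, four bonds along the chain from an amine nitrogen in a ring.

The closest measured precedent is the same exchange three bonds along the chain: a 1.3-fold lower number from compound 2 to compound 3 (0.10 log units; within the scatter). For the measured compounds named here, the large step of a 36-fold higher number from compound 1 to compound 2 (1.55 log units; beyond the scatter), like the one to compound 3, involves the loss of 4-chlorophenyl, which the present change does not touch.

In this assay, no step beyond the scatter is therefore expected, and no firm direction. The expected step is a 1.2-fold lower number from compound 3 to compound 4 (0.07 log units; within the scatter). For compound 4 the estimated value is 12000 nM, with an expected range of 6000 nM to 24000 nM.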

Compound 4, half-maximal inhibitory concentration: 10800 nM
For compound 4 the middle estimate is 1.1-fold (0.05 log units) above the measured one; the measured number falls inside the stated range.
By their numbers in this assay, from the lowest: compound 1; then compounds 4, 3 and 2 (each within the scatter of the next).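

In this assay, methyl in place of hydrogen four bonds along the chain from an amine nitrogen in a ring leaves the number within the scatter, a 1.3-fold lower number from compound 3 to compound 4 (0.11 log units; within the scatter), as the same exchange did three bonds along. Even the two exchanges taken together stay within it, a 1.6-fold lower number from compound 2 to compound 4 (0.22 log units; within the scatter), so compound 2, compound 3 and compound 4 cannot be told apart in this assay. The added chain carbons do not close the gap to compound 1, which remains large, a 22-fold higher number from compound 1 to compound 4 (1.33 log units; beyond the scatter).

No measurement at hand explains this gap. Still open, going by these compounds, is whether a plain phenyl in place of 4-chlorophenyl gives a number nearer compound 1 or compound 4, and whether a longer chain such as hexyl stays within the scatter of compound 4.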